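Amino for chloro on the core of compound 1

The source may hold more compounds than are shown below. What is called first, only, known or untested is meant among the compounds shown, and "the series" means these compounds.

Measured compounds:
compound 1, `ClCc1ccccc1Cn1cnc2c(Cl)nc(Cl)nc21`, 330 nM
compound 2, `Nc1nc(Cl)c2ncn(Cc3ccc(CCl)cc3)c2n1`, 4900 nM
compound 3, `ClCc1ccccc1Cn1cnc2ncnc(Cl)c21`, 1380 nM

In a functional assay on HCT-15 cells (Homo sapiens) for cytotoxicity, read by sulforhodamine B assay, with a stated time of 48 h (on this read-out lower numbers stand for stronger inhibition of growth and higher numbers for weaker inhibition of growth), compound 1 gives 330 nM, the lowest of the three numbers. Compound 3 gives 1380 nM, and that gap lies beyond the scatter. Compound 2 gives 4900 nM, further still from compound 1 and also beyond the scatter. No pair of these compounds differs in one place only, so no single step is known; the numbers show only that compound 1 inhibits growth more strongly than either of the others.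

Compound 4, `Nc1nc(Cl)c2ncn(Cc3ccccc3CCl)c2n1`, has not been measured. It differs from compound 1 by amino in place of chloro on an aromatic carbon. Among the compounds with values here, since compound 3, which also carries the chloro on the other position of the same ring, sits well above compound 1, and compound 2, the only measured compound carrying an amino, sits highest, the change is expected to weaken inhibition of growth; the step of a 4.5-fold higher number from compound 1 to compound 4 (0.66 log units; beyond the scatter) is estimated as a moderate rise in this assay, beyond the scatter. For compound 4 a value of 1500 nM is estimated, within a range from 500 nM to 5000 nM.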

Compound 4, concentration for 50% growth inhibition: 2700 nM
The estimate for compound 4 lay 1.8-fold (0.26 log units) below the measured number, within the range that was stated.
By their numbers in this assay, from the lowest: compound 1; then compounds 3, 4 and 2 (each within the scatter of the next, the first and the last beyond it).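

In this assay, within the data shown here, the pair gives the first single-change step in this set: amino in place of chloro on an aromatic carbon between two ring nitrogen atoms produces an 8.2-fold higher number from compound 1 to compound 4 (0.91 log units; beyond the scatter), so this one change alone weakens inhibition of growth. The earlier compounds shown here differed from each other in more than one place and could not tie any gap to this position. No measurement here bears on the reason for the rise.

The compounds shown leave open how a methylamino or a methoxy group at this position would compare with chloro and amino. They also leave open whether the step would keep its size in a compound lacking the other chloro group, the one meta to this position.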